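From 3-methoxybenzyl to 4-chlorobenzyl, starting at a limit

The source may hold more compounds than are shown below. What is called first, only, known or untested is meant among the compounds shown, and "the series" means these compounds.

Among the compounds with values here, three compounds share one core, and only two of them give numbers. In a functional assay on DU-145 cells (Homo sapiens) for cytotoxicity, read by MTT assay (on this read-out lower numbers stand for stronger inhibition and higher numbers for weaker inhibition), compound 1 (`COc1ccc2cc([C@H](C)c3nnc(SCc4ccc(Cl)cc4)n3-c3ccc(F)cc3)ccc2c1`) gives 57400 nM and compound 2 (`COc1ccc(CSc2nnc([C@@H](C)c3ccc4cc(OC)ccc4c3)n2-c2ccc(Cl)cc2)cc1`) gives 72600 nM and these two values lie within the usual scatter of each other. Compound 3 (`COc1cccc(CSc2nnc([C@@H](C)c3ccc4cc(OC)ccc4c3)n2-c2ccc(Cl)cc2)c1`) is reported only as a limit of <= 400000 nM and not as a number.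

Moving on to compound 4 (`COc1ccc2cc([C@H](C)c3nnc(SCc4ccc(Cl)cc4)n3-c3ccc(Cl)cc3)ccc2c1`) puts 4-chlorophenyl in place of 3-methoxyphenyl on a saturated chain carbon bound to a sulfur. Within the data shown here, the one measured step touching this place is a step that the limit leaves unreadable from compound 2 to compound 3 and it offers no size to carry over. The best guide is therefore the numbers themselves. Compound 1 also carries 4-chlorophenyl at this place and gives 57400 nM in this assay as its measured value.

The estimated step is a step that the limit leaves unreadable from compound 3 to compound 4 and it is expected to point toward stronger inhibition, although its size stays uncertain with only a limit at its start. For compound 4 the expected value is 60000 nM with an estimated range from 20000 nM to 180000 nM in this assay for now.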

Compound 4, half-maximal inhibitory concentration: 109000 nM
Compound 4: middle estimate off by 1.8-fold (0.26 log units), on the low side; low and high end bracket the measured number.
By their numbers in this assay, from the lowest: compounds 1, 2 and 4 (each within the scatter of the next).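

In this assay, putting chloro in place of methoxy on an aromatic carbon gives a 1.5-fold higher number from compound 2 to compound 4 (0.18 log units; within the scatter), so this first readable change at this position stays inside the normal noise of the assay. The second readable change, chloro in place of fluoro on an aromatic carbon, gives a 1.9-fold higher number from compound 1 to compound 4 (0.28 log units; within the scatter), and it also does not separate the two compounds. The steps that link compound 3 to compound 2 and to compound 4 cannot be read, because compound 3 is reported only as a limit: the limit of <= 400000 nM in this assay, at which 1 of the 4 values shown sits.

From the compounds shown here alone, what the 3-methoxybenzyl group does compared with the 4-chlorobenzyl group therefore stays open, since no number for compound 3 is available to set against the others. Also open, going by these compounds, is whether a different kind of group on the benzyl ring, such as an amine or a carboxylic acid in place of the chloro, would move the number beyond the scatter, which neither methoxy nor chloro has done among the measured compounds here.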